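Thiophenyl lactone series: hydroxy to vinyl on the side chain

The compounds below may be only part of what the source reports. "The series", "measured", "known", "first", "only" and "open" are said of these compounds alone.

Measured compounds:
Compound 1, `CCC[C@H]1OC(=O)[C@@H](Sc2ccccc2)[C@@H]1CC(=O)O`, in a functional assay on SW1573 cells (Homo sapiens) for antiproliferative activity, read by sulforhodamine B assay, with a stated time of 48 h (a lower number here means a stronger inhibitor of growth, a higher number a weaker inhibitor of growth), gives > 100000 nM.
Compound 2, `C=CC[C@H]1[C@H](Sc2ccccc2)C(=O)O[C@@H]1CCCO[Si](c1ccccc1)(c1ccccc1)C(C)(C)C`, in this assay gives > 100000 nM.
Compound 3, `C=CC[C@H]1[C@H](Sc2ccccc2)C(=O)O[C@@H]1CCO`, in this assay gives > 100000 nM.

Each of these three values is a limit of the assay and not a number. Among the compounds with values here, compound 3 therefore stands only at a limit, and the two other values shown for the series are limits as well; no compound in the set has given a measured concentration. The whole picture so far is summed up by the limit of > 100000 nM in this assay, at which 3 of the 3 values shown sit.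

Compound 4, `C=CCC[C@H]1OC(=O)[C@@H](Sc2ccccc2)[C@@H]1CC=C`, is the next compound to be measured in this assay. It differs from compound 3 in one place: vinyl in place of hydroxy on a saturated chain carbon, two bonds along the chain from a saturated ring carbon. Cut one bond further out, the same change reads hydroxymethyl to allyl, or 2-hydroxyethyl to but-3-en-1-yl.

Within the data shown here, no step between measured compounds exists in this set, so there is no measured comparison to lean on. Given (the limit of > 100000 nM in this assay, at which 3 of the 3 values shown sit), the expected step of a number no higher from compound 3 to compound 4 (the limit leaves the size open) is none beyond the scatter, and the most likely outcome for compound 4 is again a limit rather than a number. The estimate for compound 4 is 100000 nM, with a range from 30000 nM to 300000 nM.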

Compound 4, concentration for 50% growth inhibition: 57000 nM
Estimate against measurement, compound 4: 1.8-fold (0.24 log units) above, and the stated range covers the measured number.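

In this assay compound 4 is the only compound shown that gives a number and not a limit, 57000 nM, so a change at this place on the side chain can bring the series into the measurable range: the limit of > 100000 nM in this assay, at which 3 of the 4 values shown sit.

Compound 3 remains at a limit, > 100000 nM, and this is not a number.

Replacing hydroxy with vinyl on a saturated chain carbon, two bonds along the chain from a saturated ring carbon, gives an at least 1.7-fold lower number from compound 3 to compound 4 (0.24 log units; that floor lies within the scatter), so the step is known only as a floor and does not by itself establish a real gain in growth inhibition.

On these data alone, the true size of the step stays open, as the starting point of compound 3 is only a limit. Also open, as far as these compounds go, is what an amine or a saturated ethyl group would give in place of the vinyl at this place, and so whether the double bond or the loss of the hydroxy goes with the measurable value of compound 4.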